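Swapping Fluoro for Chloro on a Small Aryl Heterocycle

A few compounds are considered here, and "the series" means these few. Any claim that something is new, unique, unknown or untested is made for them only; others in the source may bear on it.

Three compounds sharing a small heterocyclic core joined to a six-membered aromatic ring have been tested in an ADME assay on L02 cells (Homo sapiens) for inhibition, read by MTT assay, with a stated time of 48 h, tested at 100 uM; a higher number here means more inhibition at the concentration tested (going by the name of the read-out), a lower number less inhibition. Compound 1, `O=c1nc(-c2ccc(F)cc2)ss1`, gives 33.7% in this assay. Compound 2, `O=c1oc(-c2ccc(F)cc2)ns1`, gives 21.7%, and compound 3, `COc1ccc(OC)c(-c2nsc(=O)o2)c1`, gives 25.3%. Among the compounds with values here, of these three numbers, the one for compound 1 is the largest, but compound 3 lies within the usual scatter of it, so the two cannot be told apart; only compound 2 sits lower by more than the scatter.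

The next compound, compound 4, `O=c1nc(-c2ccc(Cl)cc2)ss1`, is compound 1 with one change: chloro in place of fluoro on an aromatic carbon. Everything else in the molecule is kept as in compound 1. Within the data shown here, no pair of measured compounds differs in just one place, so no measured step of this kind is available to guide an expectation, and the outlook rests on compound 1 alone.

Because compound 1 gives 33.7% and the change is a single halogen for another of the same kind on the same aromatic carbon, the expected step of a number 4.3 percentage points higher from compound 1 to compound 4 (within the scatter) is small, leaning slightly upward, and likely to stay within the usual scatter. Compound 4 is therefore estimated to give about 38% in this assay, with a plausible range from 22% to 55%.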

Compound 4, a percentage reported as inhibition, at one concentration (the size of the read-out at that concentration, not a potency): 46%
The estimate for compound 4 lay 8 percentage points below the measured number; the measured number falls inside the stated range.
By their numbers in this assay, from the lowest: compounds 2, 3 and 1 (each within the scatter of the next, the first and the last beyond it); then compound 4.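

In this assay, chloro in place of fluoro gives a number 12.3 percentage points higher from compound 1 to compound 4 (beyond the scatter), even though one heavy atom leaves, one heavy atom enters, and neither group brings a hydrogen-bond donor or acceptor. Within the data shown here, the earlier compounds offered no pair differing in just one place, so this is the first direct reading of this position: the halogen on an aromatic carbon, para to a group of 6 heavy atoms, can move the read-out while the rest of the molecule stays the same. These numbers give no explanation for the rise, and nothing at hand bears on what lies behind it.

Still open, on these data alone, is whether the upward trend stops at chloro or carries on to bromo, and whether a quite different group on the same carbon, such as a methoxy, an amine or a carboxylic acid, would raise or lower the number. As far as these compounds go, it is also open whether the same swap would give a similar step on the core of compound 2, where the fluoro group sits on the same kind of ring but the heterocycle differs.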